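Allyl Ester Expected to Stay at the Assay Limit

The compounds below may be only part of what the source reports. "The series", "measured", "known", "first", "only" and "open" are said of these compounds alone.

Measured compounds:
compound 1 `O=C(OCc1ccccc1)c1ccsc1NC(=O)[C@@H]1CCCN1` gives > 250 ug/mL in a functional assay on MCF7 cells (Homo sapiens) for inhibition; on this read-out higher numbers stand for weaker inhibition of growth and lower numbers for stronger inhibition of growth.
compound 2 `CCOC(=O)c1ccsc1NC(=O)[C@@H]1CCCN1` gives > 250 ug/mL in this assay.
compound 3 `O=C1CC[C@@H](COC(=O)c2ccsc2NC(=O)[C@@H]2CCCN2)N1` gives 148 ug/mL in this assay.

Compound 1 stands at a limit of the assay, not a number, so its growth inhibition is only bounded. The same holds for compound 2; two of the three values sit at that limit (the limit of > 250 ug/mL in this assay, at which 2 of the 3 values shown sit). For the measured compounds named here, compound 3 is the only one with a number.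

Compound 4 `C=CCOC(=O)c1ccsc1NC(=O)[C@@H]1CCCN1` differs from compound 1 by vinyl in place of phenyl on a saturated chain carbon bound to an oxygen next to a carbonyl group. The closest measured step is a step that the two limits leave unreadable from compound 1 to compound 2, where a small chain also replaced the phenyl but both ends sit at the limit. The steps of an at least 1.6-fold lower number from compound 1 to compound 3 (0.22 log units; that floor lies within the scatter) and an at least 1.6-fold lower number from compound 2 to compound 3 (0.22 log units; that floor lies within the scatter) have a floor that lies within the scatter, so they give no firm direction either.

Since compound 2, with a small chain in the same place, also reports only the limit, compound 4 is expected to do the same, with an estimate of 250 ug/mL ranging from 120 ug/mL to 500 ug/mL. The expected step of a number no higher from compound 1 to compound 4 (the limit leaves the size open) is therefore none beyond the scatter.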

Compound 4, concentration for 50% growth inhibition: 96.6 ug/mL
The estimate for compound 4 lay 2.6-fold (0.41 log units) above the measured number, outside the stated range (below it).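

For the compounds shown here, at this position, on a saturated chain carbon bound to an oxygen next to a carbonyl group, vinyl gives the first steps that clear the scatter in this assay: an at least 2.5-fold lower number from compound 1 to compound 4 (0.41 log units; beyond the scatter) and an at least 2.5-fold lower number from compound 2 to compound 4 (0.41 log units; beyond the scatter). Both steps are floors rather than full sizes, as compound 1 and compound 2 each stand at a limit of the assay: the limit of > 250 ug/mL in this assay, at which 2 of the 4 values shown sit. With a 1.5-fold lower number from compound 3 to compound 4 (0.19 log units; within the scatter), compound 3 and compound 4 cannot be told apart, so two quite different groups, vinyl and 5-oxopyrrolidin-2-yl, give values within the scatter of each other.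

From the compounds shown here alone, it remains open whether the double bond of vinyl or the length of the chain goes with the lower number. An ethyl group in the same place would bear on that question, and an amine at the chain end would test a different kind of group.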